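This account rests on a few compounds, and the source may have more. Where it says the series, first, only, none or still open, it means among the compounds named here.

Compound 1, with the structure `CN1CCC(n2cc(S(=O)(=O)c3cccc(F)c3)c3cc(F)ccc32)C1`, was tested in a functional assay on HeLa cells for antagonist activity at 5-hydroxytryptamine receptor 6 (Homo sapiens), read by cAMP accumulation and immunoassay, with a stated time of 10 min (on this read-out lower numbers stand for smaller maximal responses and higher numbers for larger maximal responses), and gave 70%. Within the data shown here, the only other measured compound here is compound 2, with the structure `CN1CCC(n2cc(S(=O)(=O)c3cccc4ccccc34)c3ccccc32)C1`, which in this assay gave 98%. Of these two numbers, compound 1 stands at the lower end, and compound 2 sits higher by a margin that lies beyond the usual scatter. Among the measured compounds shown here, no two measured compounds differ in a single place, so no measured step is available to guide the next comparison directly.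

Compound 3, with the structure `O=S(=O)(c1cccc(F)c1)c1cn(C2CCCNC2)c2ccc(F)cc12`, differs from compound 1 in one spot: piperidin-3-yl in place of 1-methylpyrrolidin-3-yl on an aromatic nitrogen. For the measured compounds named here, because the two measured values for compound 1, 70%, and compound 2, 98%, are the only guides available, and nothing measured speaks to this particular swap, the step from compound 1 to compound 3 is expected to be small, with no clear direction and probably within the scatter, as a number 4 percentage points higher from compound 1 to compound 3 (within the scatter). On that basis compound 3 is estimated to give about 74% in this assay, with a plausible range from 55% to 93%.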

Compound 3, largest response reached (reported as Imax), in percent of the reference or control that the assay uses: 85%
Compound 3: the middle estimate sits 11 percentage points below what was measured; the range from low to high includes it.
By their numbers in this assay, from the lowest: compound 1; then compound 3; then compound 2.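

In this assay, placing piperidin-3-yl in place of 1-methylpyrrolidin-3-yl on an aromatic nitrogen gives a number 15 percentage points higher from compound 1 to compound 3 (beyond the scatter), so this position does respond to the group it carries, even when the two groups hold the same atoms, joined differently. The change is not a single one: the ring goes from five-membered to six-membered, and the ring nitrogen goes from having no hydrogen-bond donor to having one, so a higher maximal response here comes with both differences at once. Nothing measured here gives a reason for this step.

The compounds shown leave open whether ring size or the hydrogen-bond donor accounts for the step. A 1-methylpiperidin-3-yl group or a pyrrolidin-3-yl group on the same aromatic nitrogen would separate those two differences, and an open-chain amine such as 2-aminoethyl would show whether a ring is needed at this position at all.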